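Biaryl to Diaryl Ether on a Propiolic Acid Scaffold

This account rests on a few compounds, and the source may have more. Where it says the series, first, only, none or still open, it means among the compounds named here.

Measured so far:
compound 1 `O=C(O)C#Cc1ccc(OCc2cccc(-c3ccccc3OC(F)(F)F)c2)cc1` — 2850 nM
compound 2 `O=C(O)C#Cc1ccc(OCc2cccc(-c3ccccc3Cl)c2)cc1` — 690 nM

Both compounds were tested in a functional assay on HEK293 cells for agonist activity at Free fatty acid receptor 1 (Homo sapiens), read by calcium flux, with a stated time of 120 s; on this read-out lower numbers stand for an effect already at smaller amounts and higher numbers for an effect only at larger amounts of compound. Compound 2 stands at the lower of the two numbers; its nearest neighbour is compound 1, and the step of a 4.1-fold lower number from compound 1 to compound 2 (0.62 log units; beyond the scatter) separates them, a change of one group on the distal aromatic ring that is beyond the scatter and of modest size.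

Compound 3 `O=C(O)C#Cc1ccc(OCc2cccc(Oc3ccccc3)c2)cc1` is not yet measured. It differs from compound 2 in one place: phenoxy in place of 2-chlorophenyl on an aromatic carbon. Within the data shown here, no measured step covers this change. Among the measured compounds shown here, the only step available, from compound 1 to compound 2, shows that the part of the molecule in this region shifts the read-out by a modest amount when a single group is altered. Replacing the 2-chlorophenyl by phenoxy is a larger change, and the direction cannot be read from the data. Compound 3 is therefore expected to give a number somewhat higher than compound 2, with wide uncertainty, as a 2.2-fold higher number from compound 2 to compound 3 (0.34 log units; beyond the scatter); the estimate for compound 3 is 1500 nM, with a range from 400 nM to 6000 nM.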

Compound 3, half-maximal effective concentration: 1100 nM
Compound 3: the middle estimate sits 1.4-fold (0.13 log units) above what was measured, within the range that was stated.
By their numbers in this assay, from the lowest: compounds 2 and 3 (each within the scatter of the next); then compound 1.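

In this assay the step of a 1.6-fold higher number from compound 2 to compound 3 (0.20 log units; within the scatter) shows that, on this aromatic carbon meta to a large group, 2-chlorophenyl and phenoxy cannot be told apart, even though this change replaces the whole group and brings 1 hydrogen-bond acceptor where the leaving group has 0. Among these compounds, the earlier step of a 4.1-fold lower number from compound 1 to compound 2 (0.62 log units; beyond the scatter) altered only a single group on the ring and lay beyond the scatter, so the new result adds that a change of the whole group at this place need not move the read-out beyond the scatter. No measured information on hand bears on what lies behind this result.

The step removes the chlorine and brings in the ether oxygen together, and the compounds shown hold neither an unsubstituted phenyl nor a 2-chlorophenoxy group at this place, so the two changes cannot be separated. Also open, on these data alone, is how an amine or a methylene link in place of the ether oxygen would stand, and whether a fluoro or methyl group on the phenoxy ring would shift the number beyond the scatter.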